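A few compounds are considered here, and "the series" means these few. Any claim that something is new, unique, unknown or untested is made for them only; others in the source may bear on it.

Working notes on the series, read in a functional assay on SMMC-7721 cells (Homo sapiens) for antiproliferative activity, read by MTT assay, with a stated time of 48 h; a lower number here means a stronger inhibitor, a higher number a weaker inhibitor. Going by the values given here, compound 3 (`CC(C)=CCC[C@]1(C)/C=C/[C@@H](OC(=O)C=C(C)C)[C@](C)(O)/C=C/C(=O)/C(CN2CCCC2)=C\C1`) gives 140 nM, the lowest number of the three measured so far. Compound 2 (`CCN(CC)C/C1=C/C[C@](C)(CCC=C(C)C)/C=C/[C@@H](OC(=O)C=C(C)C)[C@](C)(O)/C=C/C1=O`) gives 570 nM, and compound 1 (`COC/C1=C/C[C@](C)(CCC=C(C)C)/C=C/[C@@H](OC(=O)C=C(C)C)[C@](C)(O)/C=C/C1=O`) gives 11000 nM, the highest of the three.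

The next member is compound 4 (`COCOC/C1=C/C[C@](C)(CCC=C(C)C)/C=C/[C@@H](OC(=O)C=C(C)C)[C@](C)(O)/C=C/C1=O`), with methoxymethoxy in place of pyrrolidin-1-yl on a saturated chain carbon bound to a double-bonded ring carbon. Like the methoxy of compound 1, the entering group holds no nitrogen.

All three measured steps lie at this same place. Diethylamino in place of methoxy gives a 19-fold lower number from compound 1 to compound 2 (1.29 log units; beyond the scatter), and pyrrolidin-1-yl in place of methoxy gives a 79-fold lower number from compound 1 to compound 3 (1.90 log units; beyond the scatter). Both are large. Between the two nitrogen groups, the change is modest, at a 4.1-fold lower number from compound 2 to compound 3 (0.61 log units; beyond the scatter). Among the compounds with values here, no measured step compares methoxymethoxy with methoxy, so the reading of compound 4 as close to compound 1 remains an assumption.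

Reversing a 79-fold lower number from compound 1 to compound 3 (1.90 log units; beyond the scatter) points to a large rise, and the expected step in this assay is estimated as a 57-fold higher number from compound 3 to compound 4 (1.76 log units; beyond the scatter). For compound 4 the estimated value is 8000 nM, with an expected range of 2500 nM to 25000 nM.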

Compound 4, half-maximal inhibitory concentration: 3250 nM
Compound 4: the middle estimate sits 2.5-fold (0.39 log units) above what was measured; the measured number falls inside the stated range.
By their numbers in this assay, from the lowest: compound 3; then compound 2; then compound 4; then compound 1.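

In this assay, the two groups without nitrogen do not give the same number at this place, on a saturated chain carbon bound to a double-bonded ring carbon: the methoxymethoxy of compound 4 gives a 3.4-fold lower number from compound 1 to compound 4 (0.53 log units; beyond the scatter) in a step that separates it from the methoxy of compound 1. Removing the nitrogen group still costs much of the activity, with a 23-fold higher number from compound 3 to compound 4 (1.37 log units; beyond the scatter) against pyrrolidin-1-yl and a 5.7-fold higher number from compound 2 to compound 4 (0.76 log units; beyond the scatter) against diethylamino as the smaller step. Across these four compounds, both groups with nitrogen therefore give lower numbers than both groups without it, and no compound shown goes against this, though the oxygen groups now cover a range of their own.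

The compounds shown leave open whether a morpholin-4-yl group, which holds both nitrogen and oxygen in one ring, or a free hydroxyl at this place would fall with the nitrogen groups or with the oxygen groups. Nothing in hand accounts for the differences between these four compounds, so the order stands only as a record of the numbers.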